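Methoxy for methyl on the cyclobutyl amide of compound 3

This account rests on a few compounds, and the source may have more. Where it says the series, first, only, none or still open, it means among the compounds named here.

compound 1, `CN1CCc2nc(C#Cc3ccccc3)sc2C1`: > 10000 nM
compound 2, `CC(C)CN1CCc2nc(C#Cc3ccccc3)sc2C1`: 650 nM
compound 3, `CC1CC(C(=O)N2CCc3nc(C#Cc4ccccc4)sc3C2)C1`: > 10000 nM

In an assay on HEK293 cells for negative allosteric modulation of metabotropic glutamate receptor 5 (Homo sapiens), read by FLIPR, with a stated time of 1 h (a lower number here means a stronger inhibitor, a higher number a weaker inhibitor), compound 2 gives 650 nM. Compound 1 reaches only the limit of this assay, > 10000 nM. Compound 3 likewise reaches only the limit of this assay, > 10000 nM, so where it stands is known as a bound and not as a number. Of the measured steps, an at least 15-fold lower number from compound 1 to compound 2 (1.18 log units; beyond the scatter), while an at least 15-fold higher number from compound 2 to compound 3 (1.18 log units; beyond the scatter) and a step that the two limits leave unreadable from compound 1 to compound 3.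

Compound 4, `COC1CC(C(=O)N2CCc3nc(C#Cc4ccccc4)sc3C2)C1`, differs from compound 3 by methoxy in place of methyl on a saturated ring carbon. Going by the values given here, the steps that lead to compound 3, an at least 15-fold higher number from compound 2 to compound 3 (1.18 log units; beyond the scatter) and a step that the two limits leave unreadable from compound 1 to compound 3, concern the group on the ring nitrogen and the amide as a whole; none of the measured steps alters the four-membered ring itself, so there is no precedent for the change at hand. Given that compound 3 sits at the limit, the expected step in this assay is none beyond the scatter, with compound 4 likely remaining at the limit as well. Compound 4 is therefore estimated at 20000 nM (range 5000 nM to 60000 nM), an expected step that the limit leaves unreadable from compound 3 to compound 4.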

Compound 4, half-maximal inhibitory concentration: > 10000 nM
Compound 4: no number, only a limit; the forecaster's own chance of this, stated with the estimate: 80%; the middle value lies beyond the limit too.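

Methoxy in place of methyl on this saturated ring carbon gives the amide series no readable value in this assay: compound 4 gives > 10000 nM, which is a limit and not a number. The steps to compound 4 from compound 3 and from compound 1 cannot be read, so this change has no measurable size here. What is new is that a second cyclobutyl amide falls short of the isobutyl amine, with (3-methoxycyclobutyl)carbonyl in place of isobutyl on the ring amine nitrogen giving an at least 15-fold higher number from compound 2 to compound 4 (1.18 log units; beyond the scatter).

From the compounds shown here alone, whether the group on this ring carbon matters at all remains open, since neither amide gives a number: the limit of > 10000 nM in this assay, at which 3 of the 4 values shown sit. Nor do the compounds shown tell whether a hydroxyl or an amine at this carbon would bring an amide within range, or whether the carbonyl rather than the four-membered ring accounts for the gap to compound 2.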